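Hepatocyte clearance notes: heteroaryl swap from compound 3 to 4

The source may hold more compounds than are shown below. What is called first, only, known or untested is meant among the compounds shown, and "the series" means these compounds.

Measured so far:
compound 1 `CC(=O)N[C@@H]1CCC[C@H](C(=O)Nc2cc(-c3cnn4c3CCCC4)ccn2)C1`: 33 uL/min
compound 2 `CC(=O)N[C@@H]1CCC[C@H](C(=O)Nc2cc(-c3cnn4c3CCCC4)c(F)cn2)C1`: 73 uL/min
compound 3 `CC(=O)N[C@@H]1CCC[C@H](C(=O)Nc2cc(-c3cnn(C)c3C)c(Cl)cn2)C1`: 10 uL/min

In an ADME assay on cells (Hepatocyte, Rattus norvegicus) for metabolic stability, using equilibrium dialysis (a higher number here means faster removal of the compound, a lower number slower removal), compound 3 gives 10 uL/min, the lowest of the three numbers, beyond the scatter from both compound 1 and compound 2. Compound 4 `CC(=O)N[C@@H]1CCC[C@H](C(=O)Nc2cc(-c3cnc4n3CCC4)c(Cl)cn2)C1` is not yet measured. It differs from compound 3 in one place: a group of 8 heavy atoms (6 carbon, 2 nitrogen; one five-membered non-aromatic ring with 1 hetero atom, one five-membered aromatic ring with 2 hetero atoms) in place of a group of 7 heavy atoms (5 carbon, 2 nitrogen; one five-membered aromatic ring with 2 hetero atoms), on an aromatic carbon.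

For the measured compounds named here, the only measured step, a 2.2-fold higher number from compound 1 to compound 2 (0.34 log units; beyond the scatter), concerns a fluoro in place of hydrogen and does not bear on the group exchanged here. Going by the values given here, no measured step exchanges the group on this aromatic carbon, so there is no direct precedent. Among the compounds with values here, compound 1 and compound 3 differ in two places and their values show only that compound 1, at 33 uL/min, sits well above compound 3. Given this, a step in this assay upward from compound 3 of modest size is expected, with wide uncertainty; the expected step is a 2.0-fold higher number from compound 3 to compound 4 (0.30 log units; within the scatter). Compound 4 is therefore estimated at 20 uL/min, in the range 8 uL/min to 50 uL/min.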

Compound 4, intrinsic clearance in a liver preparation (reported as CLH), per the amount of preparation that the assay uses: 19 uL/min
Estimate against measurement, compound 4: 1.1-fold (0.02 log units) above; measured number inside the range.
By their numbers in this assay, from the lowest: compounds 3, 4 and 1 (each within the scatter of the next, the first and the last beyond it); then compound 2.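

In this assay, the exchange of the 1,5-dimethyl-1H-pyrazol-4-yl group for the group with one five-membered aromatic ring and one five-membered non-aromatic ring gives a 1.9-fold higher number from compound 3 to compound 4 (0.28 log units; within the scatter). For the compounds shown here, this is the first reading of a change on this aromatic carbon, ortho to a chloro group and opposite the ring nitrogen, and it does not separate the two groups in this assay. No measurement at hand offers an account of this result.

The compounds shown leave open whether the same exchange gives a comparable step when fluoro or hydrogen replaces the chloro group. They also leave open how this assay reads when this aromatic carbon carries a five-membered aromatic ring bearing a primary amine or a carboxylic acid.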